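From 2-chlorophenyl to 4-methoxyphenyl on a shared core

This account rests on a few compounds, and the source may have more. Where it says the series, first, only, none or still open, it means among the compounds named here.

Compound 1 `Nc1ccccc1NC(=O)CCCNCC(=O)Nc1cccc(Cl)c1` gives 75000 nM
Compound 2 `Nc1ccccc1NC(=O)CCCNCC(=O)Nc1cccc([N+](=O)[O-])c1` gives 22500 nM
Compound 3 `Nc1ccccc1NC(=O)CCCNCC(=O)Nc1ccccc1Cl` gives > 100000 nM

In a functional assay on HCT-116 cells (Homo sapiens) for inhibition, read by MTT assay, with a stated time of 2 days (on this read-out higher numbers stand for weaker inhibition of growth and lower numbers for stronger inhibition of growth), compound 3 gives > 100000 nM as a limit of the assay and not a number. Within the data shown here, compound 4 `COc1ccc(NC(=O)CNCCCC(=O)Nc2ccccc2N)cc1` has 4-methoxyphenyl in place of 2-chlorophenyl on an amide-type nitrogen in a change no measured step covers. The nearest guides are other changes at that nitrogen. These are an at least 4.4-fold higher number from compound 2 to compound 3 (0.64 log units; beyond the scatter) and an at least 1.3-fold higher number from compound 1 to compound 3 (0.12 log units; that floor lies within the scatter) while the two numbered compounds differ by a 3.3-fold lower number from compound 1 to compound 2 (0.52 log units; beyond the scatter) as well. A modest move to a lower number is therefore expected, and the estimated step is an at least 2.0-fold lower number from compound 3 to compound 4 (0.30 log units; that floor lies within the scatter) in this assay. For compound 4 the expected value is 50000 nM with an estimated range of 18000 nM to 120000 nM here.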

Compound 4, concentration for total growth inhibition: 44000 nM
Compound 4: middle estimate off by 1.1-fold (0.06 log units), on the high side; low and high end bracket the measured number.
By their numbers in this assay, from the lowest: compounds 2, 4 and 1 (each within the scatter of the next, the first and the last beyond it). At a limit, above all of these: compound 3.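

In this assay compound 3 stands at a limit of the assay and not at a number: the limit of > 100000 nM in this assay, at which 1 of the 4 values shown sits. Against that limit, 4-methoxyphenyl on the amide-type nitrogen gives an at least 2.2-fold lower number from compound 3 to compound 4 (0.35 log units; beyond the scatter) and so brings a measured number back. The steps of a 2.0-fold higher number from compound 2 to compound 4 (0.29 log units; within the scatter) and a 1.7-fold lower number from compound 1 to compound 4 (0.23 log units; within the scatter) both lie within the scatter, so compound 4 cannot be told apart from compound 2 or from compound 1 here.

Going by these compounds, how an amine or a carboxylic acid on this phenyl ring would read remains open. So does the effect of a longer chain between the two amides of the shared core.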